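Thiophene-substituent change in a bicyclic amine series: cytotoxicity notes

A few compounds are considered here, and "the series" means these few. Any claim that something is new, unique, unknown or untested is made for them only; others in the source may bear on it.

Measured compounds:
- compound 1, `CSc1ccc(CN[C@@H]2C[C@H]3C[C@@H]([C@H]2C)C3(C)C)s1`: 25000 nM
- compound 2, `CCc1csc(CN[C@@H]2C[C@H]3C[C@@H]([C@H]2C)C3(C)C)c1`: 25000 nM

In an ADME assay on MDCK cells (Canis lupus familiaris) for cytotoxicity, read by microscopy, with a stated time of 48 h (a lower number here means that less compound is tolerated, a higher number that more compound is tolerated), compound 1 gives 25000 nM. In this assay compound 2 gives 25000 nM, which is level with compound 1 at the digits recorded; the two values lie within the scatter of each other, so no order between them can be drawn. The two measured compounds share the same bicyclic amine core and differ only in the group carried on the thiophene ring, and that difference leaves the cytotoxicity reading unchanged.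

Compound 3, `C[C@H]1[C@H](NCc2cc(C3CCCC3)cs2)C[C@H]2C[C@@H]1C2(C)C`, is not yet measured. The change from compound 2 is cyclopentyl in place of ethyl on an aromatic carbon

in words: cyclopentyl in place of ethyl on an aromatic carbon

Within the data shown here, no step between measured compounds is available to calibrate this change. Given that compound 1 and compound 2 sit at the same reading, the expected step of a 1.3-fold lower number from compound 2 to compound 3 (0.10 log units; within the scatter) is small, at most a modest move toward a lower number, and possibly none beyond the scatter. For compound 3 the estimate in this assay is 20000 nM, with a range from 8000 nM to 50000 nM.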

Compound 3, minimum cytotoxic concentration: 1560 nM
Estimate against measurement, compound 3: 13-fold (1.11 log units) above; measured number below the stated range.
By their numbers in this assay, from the lowest: compound 3; then compounds 1 and 2 (each within the scatter of the next).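

In this assay the move a 16-fold lower number from compound 2 to compound 3 (1.20 log units; beyond the scatter) shows that the group on this aromatic carbon, two ring bonds from the ring sulfur and two ring bonds from the ring atom that bears a large group, can shift the reading well beyond the scatter. With ethyl leaving and cyclopentyl entering, the reading responds to a change in which neither group carries a hydrogen-bond donor, a hydrogen-bond acceptor or a net charge, so those counts do not distinguish the two compounds. Nothing measured on these compounds bears on why the reading falls, and the step stands here as an observation without an explanation.

Going by these compounds, a single step cannot separate the added carbon count from the presence of the five-membered non-aromatic ring, so it remains open which of the two goes with the lower number. An open pentyl chain at this place would address that question, while a cyclopropyl group or a primary amine there would show whether the reading follows group size or also responds to a group that carries a hydrogen-bond donor.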